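Imidazolyl in Place of Butyl: What Tolerance to Expect

The source may hold more compounds than are shown below. What is called first, only, known or untested is meant among the compounds shown, and "the series" means these compounds.

Compound 1 `CCCCc1ccc(C(=O)/C=C/c2ccc([N+](=O)[O-])s2)cc1` was tested in an ADME assay on THP-1 cells (Homo sapiens) for cytotoxicity, read by resazurin assay, with a stated time of 72 h (a lower number here means that less compound is tolerated, a higher number that more compound is tolerated), where compound 1 gives 17100 nM, the highest of the two numbers at hand. Compound 2 `O=C(/C=C/c1ccc([N+](=O)[O-])o1)c1ccc(Br)cc1` gives 13400 nM in this assay; the two values lie within the usual scatter, so neither stands apart. Compound 3 `O=C(/C=C/c1ccc([N+](=O)[O-])s1)c1ccc(-n2ccnc2)cc1` has not yet been measured. It differs from compound 1 in one place: 1H-imidazol-1-yl in place of butyl on an aromatic carbon. Among the compounds with values here, no measured pair shows such a change, so there is no direct guide. Compound 3 is expected to stay near compound 1, with a step of a 1.2-fold higher number from compound 1 to compound 3 (0.07 log units; within the scatter) that is not clearly beyond the scatter. The estimate for compound 3 is 20000 nM, within 8000 nM to 50000 nM.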

Compound 3, half-maximal cytotoxic concentration: 23400 nM
Beside the measured number, compound 3's estimate is 1.2-fold (0.07 log units) below it; low and high end bracket the measured number.
By their numbers in this assay, from the lowest: compounds 2, 1 and 3 (each within the scatter of the next).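

Within the data shown here, on this aromatic carbon, para to a large group, 1H-imidazol-1-yl in place of butyl gives a 1.4-fold higher number from compound 1 to compound 3 (0.14 log units; within the scatter) in this assay, the first single-place change that can be read in this set. An open carbon chain can thus give way to a five-membered aromatic ring with 2 hetero atoms, and compound 3 still cannot be told apart from compound 1. Nothing at hand explains this result. Still open, going by these compounds, is whether an amine, a carboxylic acid or a longer chain at this position would also stay within the scatter.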